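Shortening and Saturating the Ester Chain in Compound 4

The source may report more compounds than this note shows. Statements on the series, on what has been measured and on what is new or still open speak of the compounds shown alone.

Measured compounds:
compound 1 `CCCCCCCC/C=C/CCCCCCCC(=O)O[C@H]1[C@H](O)[C@H](n2ccc(N)nc2=O)O[C@@H]1CO` gives 0.05 ug/mL in a functional assay on HeLa cells (Homo sapiens) for cytotoxicity, read by cell counting, with a stated time of 48 h; a higher number here means that more compound is needed for the effect, a lower number that less compound is needed
compound 2 `CCCCCCCC(=O)O[C@H]1[C@H](O)[C@H](n2ccc(N)nc2=O)O[C@@H]1CO` gives 0.1 ug/mL in this assay
compound 3 `CCCCCCCC/C=C\CCCCCCCCCCCC(=O)O[C@H]1[C@H](O)[C@H](n2ccc(N)nc2=O)O[C@@H]1CO` gives 0.16 ug/mL in this assay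

Compound 3 has the highest of the three numbers in this assay. It sits closest to compound 2, a gap within the scatter, and furthest from compound 1, a gap beyond the scatter. Compound 4 `CCCCCCCCCCCCCCCCCC(=O)O[C@H]1[C@H](O)[C@H](n2ccc(N)nc2=O)O[C@@H]1CO` is not yet measured. It differs from compound 3 by hexyl in place of dec-1-en-1-yl on a saturated chain carbon, ten or more bonds along the chain from a carbonyl carbon.

Within the data shown here, the only measured step that bears on this change is the removal of a long tail from compound 1: a 2.0-fold higher number from compound 1 to compound 2 (0.30 log units; within the scatter). That step stayed within the scatter, and the values of compound 1 and compound 3 differ more than the scatter without a single-place step between them. Because a 2.0-fold higher number from compound 1 to compound 2 (0.30 log units; within the scatter) shows that a large loss of chain changed little, the step from compound 3 to compound 4 is expected to be small: a 1.3-fold lower number from compound 3 to compound 4 (0.12 log units; within the scatter), toward a slightly lower number. Compound 4 is therefore estimated at 0.12 ug/mL, with a range from 0.04 ug/mL to 0.4 ug/mL.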

Compound 4, concentration for half-maximal effect: 0.13 ug/mL
Compound 4: the middle estimate sits 1.1-fold (0.03 log units) below what was measured; the measured number falls inside the stated range.
By their numbers in this assay, from the lowest: compounds 1, 2, 4 and 3 (each within the scatter of the next, the first and the last beyond it).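

In this assay, hexyl in place of dec-1-en-1-yl on a saturated chain carbon gives a 1.2-fold lower number from compound 3 to compound 4 (0.09 log units; within the scatter) and so leaves the number within the scatter even though the double bond goes. Decyl in place of hydrogen, seven bonds along the chain from a carbonyl carbon, gives a 1.3-fold higher number from compound 2 to compound 4 (0.11 log units; within the scatter) and adds a second comparison within the scatter, this time with a fully saturated chain at both ends of the step. Among these compounds, the one step here beyond the scatter is the modest 2.6-fold higher number from compound 1 to compound 4 (0.41 log units; beyond the scatter) for the exchange of one chain end for another of equal size at that same place.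

From the compounds shown here alone, whether an amine, a carboxylic acid or a chain longer than that of compound 3 at the chain end would shift the number stays open. Nothing shown here explains these steps.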